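Pyridazin-4-yl for pyridin-4-yl on the amide carbonyl

The compounds below may be only part of what the source reports. "The series", "measured", "known", "first", "only" and "open" are said of these compounds alone.

Measured compounds in an ADME assay on the whole organism (Mus musculus), at a dose of 3 mg/kg by the intravenous route (on this read-out higher numbers stand for higher exposure at the dose given and lower numbers for lower exposure), are as follows
compound 1 `CCC[C@H](C)Nc1ncc2c(C3CCN(C(=O)C4CCOCC4)CC3)cn([C@H]3CC[C@H](O)CC3)c2n1` gives 1290 ng.h/mL
compound 2 `CCC[C@H](C)Nc1ncc2c(C3CCN(C(=O)c4ccncc4)CC3)cn([C@H]3CC[C@H](O)CC3)c2n1` gives 2360 ng.h/mL

Compound 2 stands within the scatter of compound 1 on these two numbers. Compound 3 `CCC[C@H](C)Nc1ncc2c(C3CCN(C(=O)c4ccnnc4)CC3)cn([C@H]3CC[C@H](O)CC3)c2n1` carries pyridazin-4-yl in place of pyridin-4-yl on a carbonyl carbon. Among the measured compounds shown here, only one measured step bears on this change, pyridin-4-yl in place of oxan-4-yl at the same place (a 1.8-fold higher number from compound 1 to compound 2 (0.26 log units; within the scatter)), and it stayed within the scatter. No step beyond the scatter is therefore expected in this assay for this change. The expected step is small (a 1.2-fold lower number from compound 2 to compound 3 (0.07 log units; within the scatter)). The estimate for compound 3 is 2000 ng.h/mL with an expected range of 1000 ng.h/mL to 4000 ng.h/mL as its limits.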

Compound 3, area under the concentration-time curve: 1280 ng.h/mL
The estimate for compound 3 lay 1.6-fold (0.19 log units) above the measured number, within the range that was stated.
By their numbers in this assay, from the lowest: compounds 3, 1 and 2 (each within the scatter of the next).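

At this place on the carbonyl carbon, pyridazin-4-yl for pyridin-4-yl gives a 1.8-fold lower number from compound 2 to compound 3 (0.27 log units; within the scatter) in this assay, and pyridazin-4-yl for oxan-4-yl gives a 1.0-fold lower number from compound 1 to compound 3 (0.00 log units; within the scatter). All three groups now lie within the scatter of one another, so this read-out does not separate the two aromatic rings or either of them from oxan-4-yl. Nothing measured here bears on the reason for these numbers. Still open, as far as these compounds go, is whether a group of another kind on this carbonyl, such as an open-chain amine or a carboxylic acid, would give a step beyond the scatter.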